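Methoxy on the Core: Solubility Expected at the Limit

The source may report more compounds than this note shows. Statements on the series, on what has been measured and on what is new or still open speak of the compounds shown alone.

compound 1, `CC(C)Nc1nc(NCc2ccco2)c2ccccc2n1`: >= 30000 nM
compound 2, `CC(C)Nc1nc(NCc2ccco2)c2cc(Cl)ccc2n1`: >= 30000 nM
compound 3, `Cc1ccc2c(NCc3ccco3)nc(NC(C)C)nc2c1`: >= 30000 nM

In a physicochemical assay for solubility, at pH 2 (on this read-out lower numbers stand for lower solubility and higher numbers for higher solubility), compound 1 gives only a limit of the assay, not a number. For compound 2 the reading is likewise a limit. For compound 3 it is a limit as well. So all three measured values sit at the limit of >= 30000 nM in this assay, at which 3 of the 3 values shown sit, and where compound 1 truly stands above that limit cannot be told from these numbers.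

The change under consideration takes compound 1 to compound 4, `COc1cccc2c(NCc3ccco3)nc(NC(C)C)nc12`: methoxy in place of hydrogen on an aromatic carbon. For the measured compounds named here, two measured steps touch the same kind of change, a substituent entering on an aromatic carbon of the core of compound 1. The step from compound 1 to compound 2 was a step that the two limits leave unreadable from compound 1 to compound 2, and the step from compound 1 to compound 3 was a step that the two limits leave unreadable from compound 1 to compound 3. Neither gives a readable size, since both ends sit at the limit.

Because every value shown sits at the limit of >= 30000 nM in this assay, at which 3 of the 3 values shown sit, compound 4 is expected to give a reading at the limit too, with no step beyond the scatter. The estimated step from compound 1 to compound 4 in this assay is therefore a number no higher from compound 1 to compound 4 (the limit leaves the size open), and compound 4 is estimated at 30000 nM, between 15000 nM and 60000 nM.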

Compound 4, solubility: >= 30000 nM
Compound 4 gave a limit, no number; the forecaster's own chance of this, stated with the estimate: 80%; the middle value sits exactly at the limit.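

In this assay compound 4 gives >= 30000 nM as a limit and not a number. For the compounds shown here, compound 1 also sits at a limit, so no step from compound 1 to compound 4 can be read. The compounds shown leave open where compound 1 and compound 4 truly stand, and whether methoxy in place of hydrogen changes the reading at all.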